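Benzyl ether to phenol on two related cores

A few compounds are considered here, and "the series" means these few. Any claim that something is new, unique, unknown or untested is made for them only; others in the source may bear on it.

Measured compounds:
compound 1, `COc1ccc(-c2sccc2-c2cc(OC)c(OC)c(OC)c2)cc1OCc1ccccc1`
compound 2, `COc1ccc(-c2sccc2-c2cc(OC)c(OC)c(OC)c2)cc1O`
compound 3, `CCOC(=O)c1cc(-c2ccc(OC)c(OCc3ccccc3)c2)c(-c2cc(OC)c(OC)c(OC)c2)s1`

In a functional assay on SGC-7901 cells (Homo sapiens) for antiproliferative activity, read by MTT assay, with a stated time of 72 h (a higher number here means a weaker inhibitor, a lower number a stronger inhibitor), compound 1 gives only a limit of the assay, > 100000 nM. Compound 2, in this assay, gives 580 nM. Compound 3 also gives only a limit in this assay, > 100000 nM. The difference between the core of compound 3 and the core of compound 1 is not broken down here.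

The change from compound 1 to compound 2 is hydrogen in place of benzyl on an oxygen on an aromatic ring. It produced an at least 170-fold lower number from compound 1 to compound 2 (2.23 log units; beyond the scatter). Since compound 1 sits at the limit of > 100000 nM in this assay, at which 2 of the 3 values shown sit, the true size of that step is known only as a lower bound.

Compound 4, `CCOC(=O)c1cc(-c2ccc(OC)c(O)c2)c(-c2cc(OC)c(OC)c(OC)c2)s1`, has not yet been measured. It differs from compound 3 by hydrogen in place of benzyl on an oxygen on an aromatic ring, the same change as that from compound 1 to compound 2, at the same kind of place. Compound 3 also sits at the limit of > 100000 nM in this assay, at which 2 of the 3 values shown sit, so the starting point matches that of compound 1.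

The step from compound 3 to compound 4 is expected to be an at least 66-fold lower number from compound 3 to compound 4 (1.82 log units; beyond the scatter), resting on the measured step from compound 1 to compound 2 and on the shared limit of compound 3. Compound 4 is estimated at 1500 nM, between 300 nM and 20000 nM, with the core difference from compound 2 left as open uncertainty.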

Compound 4, half-maximal inhibitory concentration: 20000 nM
The estimate for compound 4 lay 13-fold (1.12 log units) below the measured number; the measured number falls inside the stated range.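

In this assay, benzyloxy to hydroxy again lowers the number, an at least 5.0-fold lower number from compound 3 to compound 4 (0.69 log units; beyond the scatter), so the direction of the change carries over from the core of compound 1 to the core of compound 3. Set side by side, the two steps read: the same change on two cores in this assay, an at least 170-fold lower number (2.23 log units; beyond the scatter) from compound 1 to compound 2 and an at least 5.0-fold lower number (0.69 log units; beyond the scatter) from compound 3 to compound 4; the limit leaves it open whether they differ Compound 1 and compound 3 each stand at a limit of the assay, so neither step has a known true size, and these two pairs do not show whether the change is worth the same on both cores or how far it would carry to any further core.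

The compounds shown leave open whether the free hydroxy itself is needed, since only benzyl and hydrogen appear on that oxygen, and a methyl or an ethyl there, or an amine in place of the hydroxy, would test this. They also leave open how the hydroxy compound on the core of compound 3 would respond if its ethyl ester gave way to a carboxylic acid or an amide.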